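The compounds below may be only part of what the source reports. "The series", "measured", "known", "first", "only" and "open" are said of these compounds alone.

In a functional assay on MDA-MB-231 cells (Homo sapiens) for inhibition, read by MTT assay, with a stated time of 48 h (a lower number here means a stronger inhibitor of growth, a higher number a weaker inhibitor of growth), compound 1 `S=C(NCc1ccccc1)Nc1ccc2ncnc(Nc3ccccc3Br)c2c1` gives > 30000 nM, which is a limit of the assay and not a number. Compound 2 `Cc1cccc(Nc2ncnc3ccc(NC(=S)NCc4ccccc4)cc23)c1` reads 19500 nM, and compound 3 `S=C(NCc1ccccc1)Nc1ccc2ncnc(Nc3ccc(-c4ccccc4)cc3)c2c1` reads 8400 nM, the lower of these two numbers by a margin beyond the scatter. Among the measured compounds shown here, compound 3 therefore stands lowest among the actual numbers so far. The next structure, compound 4 `Oc1ccc(Nc2ncnc3ccc(NC(=S)NCc4ccccc4)cc23)cc1`, carries hydroxy in place of phenyl on an aromatic carbon, para to a large group: hydroxy in place of phenyl on an aromatic carbon. For the measured compounds named here, no measured step makes this exchange. The only one available is an at least 1.5-fold lower number from compound 1 to compound 2 (0.18 log units; that floor lies within the scatter), and it concerns 3-methylphenyl in place of 2-bromophenyl, so it offers little guidance on size. Still, compound 3 holds the phenyl and sits lowest, while compound 2 lacks it and gives 19500 nM, so a move towards a higher number, meaning a weaker inhibitor of growth, is expected. The expected change is a 2.0-fold higher number from compound 3 to compound 4 (0.31 log units; beyond the scatter). For compound 4 the estimated value is 17000 nM, with an expected range of 8000 nM to 30000 nM.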

Compound 4, concentration for 50% growth inhibition: 27000 nM
Compound 4: middle estimate off by 1.6-fold (0.20 log units), on the low side, and the stated range covers the measured number.
By their numbers in this assay, from the lowest: compound 3; then compounds 2 and 4 (each within the scatter of the next). At a limit, above all of these: compound 1.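

In this assay, among the compounds shown here, replacing phenyl with hydroxy on this aromatic carbon, para to a large group, gives the first direct reading of that place: a 3.2-fold higher number from compound 3 to compound 4 (0.51 log units; beyond the scatter). The 4-hydroxyphenyl group cannot be told apart from the 3-methylphenyl group, as this step lies within the scatter: a 1.4-fold higher number from compound 2 to compound 4 (0.14 log units; within the scatter). The exchange of 2-bromophenyl for 4-hydroxyphenyl gives only a floor: an at least 1.1-fold lower number from compound 1 to compound 4 (0.04 log units; that floor lies within the scatter). That step cannot be read further, because compound 1 stands at a limit of the assay and not a number: the limit of > 30000 nM in this assay, at which 1 of the 4 values shown sits.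

The compounds shown leave open whether losing the phenyl ring or gaining the hydroxy sets the size of this step. Going by these compounds, how an amine, a methoxy group or a carboxylic acid on this same carbon would read also stays open.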